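Aryl-for-oxanyl exchange at the pyridine-adjacent position, cytotoxicity

The source may report more compounds than this note shows. Statements on the series, on what has been measured and on what is new or still open speak of the compounds shown alone.

Compound 1 `COc1nc(-c2ccc(F)cc2)ccc1[C@@H](c1ccccc1)[C@@](O)(CCN(C)C)c1cccc2ccccc12` in a toxicity assay on HeLa cells (Homo sapiens) for cytotoxicity (a higher number here means that more compound is tolerated, a lower number that less compound is tolerated), sits at a limit, > 64 ug/mL. For the measured compounds named here, compound 2 `COc1nc(C2CCOCC2)ccc1[C@@H](c1ccccc1)[C@@](O)(CCN(C)C)c1cccc2ccccc12` in this assay gives 22.5 ug/mL, the only number in the set. The remaining value, that of compound 1, is a limit (the limit of > 64 ug/mL in this assay, at which 1 of the 2 values shown sits). Going by the values given here, the one measured step, an at least 2.8-fold lower number from compound 1 to compound 2 (0.45 log units; beyond the scatter), is the sole comparison available. Compound 3 `COc1nc(-c2cnsc2)ccc1[C@@H](c1ccccc1)[C@@](O)(CCN(C)C)c1cccc2ccccc12` carries 1,2-thiazol-4-yl in place of oxan-4-yl on an aromatic carbon. Since the 4-fluorophenyl analogue compound 1 gave > 64 ug/mL, an aromatic ring at that carbon is expected to move the number back upward, by a 1.8-fold higher number from compound 2 to compound 3 (0.25 log units; within the scatter). Compound 3 is therefore estimated at 40 ug/mL, between 15 ug/mL and 80 ug/mL.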

Compound 3, half-maximal cytotoxic concentration: 28.8 ug/mL
For compound 3 the middle estimate is 1.4-fold (0.14 log units) above the measured one, within the range that was stated.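

In this assay, an aromatic ring at this carbon does not by itself separate 1,2-thiazol-4-yl from oxan-4-yl, which stay within the scatter, a 1.3-fold higher number from compound 2 to compound 3 (0.11 log units; within the scatter). The exchange of 4-fluorophenyl for 1,2-thiazol-4-yl lies beyond the scatter, an at least 2.2-fold lower number from compound 1 to compound 3 (0.34 log units; beyond the scatter), so among the three groups only 4-fluorophenyl stands apart. The value of compound 1 is a limit, not a number: the limit of > 64 ug/mL in this assay, at which 1 of the 3 values shown sits.

Open, as far as these compounds go, is whether a plain phenyl ring without fluorine would side with 4-fluorophenyl or with the other two groups. The same holds for a piperidin-4-yl ring, which carries an amine, at this carbon.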